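This account rests on a few compounds, and the source may have more. Where it says the series, first, only, none or still open, it means among the compounds named here.

Of the compounds shown here, three sharing one core have been measured in a functional assay on SGC-7901 cells (Homo sapiens) for cytotoxicity, read by MTT assay, with a stated time of 48 h; on this read-out lower numbers stand for stronger inhibition and higher numbers for weaker inhibition. Compound 1 (`Cc1ccc(-c2nnc(SCCn3c([N+](=O)[O-])cnc3C)o2)cc1`) gives 12500 nM, compound 2 (`CCOc1ccc(-c2nnc(SCCn3c([N+](=O)[O-])cnc3C)o2)cc1`) gives 14100 nM and compound 3 (`Cc1ncc([N+](=O)[O-])n1CCSc1nnc(-c2ccccc2F)o1`) gives 33700 nM. Compound 3 thus has the highest number of the three, and its gaps to both others lie beyond the scatter, which makes it the weakest inhibitor so far.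

Compound 4 (`Cc1ncc([N+](=O)[O-])n1CCSc1nnc(-c2ccc(Cl)cc2)o1`) alters compound 3 in one place: 4-chlorophenyl in place of 2-fluorophenyl on an aromatic carbon. Here 4-chlorophenyl stands in place of 2-fluorophenyl on an aromatic carbon of the five-membered aromatic ring with 2 nitrogen and 1 oxygen.

For the measured compounds named here, two measured steps bear on this change. The closer one, with 2-fluorophenyl in place of 4-methylphenyl, is a 2.7-fold higher number from compound 1 to compound 3 (0.43 log units; beyond the scatter), a modest rise. The other, with ethoxy in place of methyl on an aromatic carbon, is a 1.1-fold higher number from compound 1 to compound 2 (0.05 log units; within the scatter), so that exchange left the number unmoved. Compound 4 keeps a substituent at the same place on the phenyl as compound 1, and its number is therefore expected to return towards that of compound 1, which gives 12500 nM. Going by the values given here, no chlorinated compound has been measured, so this remains an inference. The expected change is a 2.2-fold lower number from compound 3 to compound 4 (0.35 log units; beyond the scatter), a modest move towards stronger inhibition. For compound 4 the estimated value is 15000 nM, with an expected range from 7000 nM to 32000 nM.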

Compound 4, half-maximal inhibitory concentration: 31900 nM
Compound 4: the middle estimate sits 2.1-fold (0.33 log units) below what was measured; measured number inside the range.
By their numbers in this assay, from the lowest: compounds 1 and 2 (each within the scatter of the next); then compounds 4 and 3 (each within the scatter of the next).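

In this assay, 4-chlorophenyl in place of 2-fluorophenyl gives a 1.1-fold lower number from compound 3 to compound 4 (0.02 log units; within the scatter), so this exchange leaves the number unmoved and a substituent in the position held by the methyl of compound 1 does not by itself restore the lower number. Chloro in place of methyl gives a 2.6-fold higher number from compound 1 to compound 4 (0.41 log units; beyond the scatter) and chloro in place of ethoxy gives a 2.3-fold higher number from compound 2 to compound 4 (0.35 log units; beyond the scatter), which shows that the identity of this phenyl substituent matters: among these four compounds, the two bearing a halogen have the higher numbers and the methyl and ethoxy compounds the lower, with none going against this split. No evidence is available to explain this split.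

The compounds shown have only one fluorophenyl and one chlorophenyl, with the halogen placed differently on each, so they leave open whether the split follows the halogen itself or would survive in a 4-fluorophenyl or 2-chlorophenyl compound. They also leave open how an amine, a carboxylic acid or a longer alkoxy chain in place of the ethoxy group would behave on this phenyl.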